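The compounds below may be only part of what the source reports. "The series", "measured", "known", "first", "only" and "open" are said of these compounds alone.

Measured compounds:
compound 1 `C=Cc1cc(CNC(=O)CCc2ccc(C(C)(C)C)cc2)cc(F)c1NS(C)(=O)=O` — 25 nM
compound 2 `CC(C)(C)c1ccc(CCC(=S)NCc2ccc(NS(C)(=O)=O)c(I)c2)cc1` — 300 nM

In a functional assay for antagonist activity at transient receptor potential cation channel subfamily V member 1 (Rattus norvegicus) (a higher number here means a weaker inhibitor, a lower number a stronger inhibitor), compound 1 gives 25 nM and compound 2 gives 300 nM. Compound 2 thus stands highest of the two numbers, above compound 1 by a gap beyond the usual scatter.

Compound 3 `CC(=O)c1cc(CNC(=S)CCc2ccc(C(C)(C)C)cc2)ccc1NS(C)(=O)=O` has not yet been measured in this assay. It differs from compound 2 by acetyl in place of iodo on an aromatic carbon, the new group sitting ortho to a methanesulfonamido group. Among the compounds with values here, no step between measured compounds covers this change. A modest lowering of the number is expected, so the step of a 2.0-fold lower number from compound 2 to compound 3 (0.30 log units; within the scatter) is estimated to be small and downward. Compound 3 is expected to give about 150 nM in this assay, within 40 nM to 600 nM.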

Compound 3, half-maximal inhibitory concentration: 1000 nM
For compound 3 the middle estimate is 6.7-fold (0.82 log units) below the measured one, outside the stated range (above it).
By their numbers in this assay, from the lowest: compound 1; then compound 2; then compound 3.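

In this assay, the aromatic carbon ortho to a methanesulfonamido group proves sensitive to its substituent: acetyl in place of iodo gives a 3.3-fold higher number from compound 2 to compound 3 (0.52 log units; beyond the scatter). This single pair puts acetyl on the weaker side of iodo at this position, with the rest of the structure unchanged. Nothing measured on these compounds accounts for the step.

This one step cannot separate the carbonyl oxygen of acetyl from its added carbon atoms. Going by these compounds, how methyl, chloro or a nitrile would compare with iodo and acetyl at this position remains open.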